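Trimming the chain on a pyrimidinone-thioether series

The source may hold more compounds than are shown below. What is called first, only, known or untested is meant among the compounds shown, and "the series" means these compounds.

Three analogues were measured in an ADME assay on C1866 cells (Homo sapiens) for cytotoxicity, read by MTT assay, with a stated time of 72 h; a higher number here means that more compound is needed for the effect, a lower number that less compound is needed. Compound 1 `CC(C)c1c(CC2CCCCC2)nc(SCC(=O)c2ccccc2)[nH]c1=O` gave 0.025 nM, compound 3 `CCc1c(CC2CCCCC2)nc(SCC(=O)c2ccccc2)[nH]c1=O` gave 0.012 nM, and compound 2 `CCc1c(CC2CCCCC2)nc(SCC(=O)c2ccc(OC)cc2)[nH]c1=O` gave 0.217 nM, the highest number of the three. The change from compound 1 to compound 3, (hydrogen in place of methyl on a saturated chain carbon bound to an aromatic carbon and a saturated chain carbon), produced a 2.1-fold lower number from compound 1 to compound 3 (0.32 log units; beyond the scatter). Compound 4 `COc1ccc(C(=O)CSc2nc(CC3CCCCC3)c(C)c(=O)[nH]2)cc1` is not yet measured; it arises from compound 2 by hydrogen in place of methyl on a saturated chain carbon bound to an aromatic carbon, the same kind of change, though here the saturated chain carbon is bound only to an aromatic carbon rather than to an aromatic carbon and a saturated chain carbon. The difference between the cores of compound 1 and compound 2 is not broken down here. Compound 4 is expected to show a 2.2-fold lower number from compound 2 to compound 4 (0.34 log units; beyond the scatter) in this assay, resting on the modest step from compound 1 to compound 3 a 2.1-fold lower number from compound 1 to compound 3 (0.32 log units; beyond the scatter). The estimate for compound 4 is therefore 0.1 nM, between 0.04 nM and 0.3 nM.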

Compound 4, half-maximal effective concentration: 1060 nM
Compound 4: middle estimate off by 11000-fold (4.03 log units), on the low side; the whole stated range lies below it.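

In this assay the change from ethyl to methyl on a saturated chain carbon bound to an aromatic carbon gave a 4900-fold higher number from compound 2 to compound 4 (3.69 log units; beyond the scatter) and so ran opposite to the earlier step, with a far larger size. The change therefore did not carry over from one core to the other: the same change on two cores in this assay, a 2.1-fold lower number (0.32 log units; beyond the scatter) from compound 1 to compound 3 and a 4900-fold higher number (3.69 log units; beyond the scatter) from compound 2 to compound 4, 10000-fold (4.01 log units) apart, beyond the scatter of two such steps. This does not show which difference between the cores sets the two steps apart, and two pairs cannot give a rule for the series.

The compounds shown leave open how the methyl compound lacking the methoxy group would read. They also leave open whether a propyl chain, or a hydroxyl group in place of methoxy, would follow compound 3 or compound 4.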